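A few compounds are considered here, and "the series" means these few. Any claim that something is new, unique, unknown or untested is made for them only; others in the source may bear on it.

Measured so far:
Compound 1, `CCOc1ccc(NC(=O)Nn2c(CC)nc3ccccc3c2=O)cc1` — 50%
Compound 2, `CCc1nc2ccccc2c(=O)n1NC(=O)Nc1ccc(Br)cc1` — 54%

Among the measured compounds shown here, in a functional assay on the whole organism (strain albino) with Mus musculus as the target, at a dose of 100 mg/kg by the intraperitoneal route (a higher number here means more inhibition at the dose given (going by the name of the read-out), a lower number less inhibition), compound 2 gives 54%, the higher of the two numbers so far, though only in name: the one neighbour is compound 1 with 50%, and the step between them, a number 4 percentage points higher from compound 1 to compound 2 (within the scatter), lies within the scatter, so the two compounds cannot be told apart on these numbers.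

Compound 3, `CCc1nc2ccccc2c(=O)n1NC(=O)Nc1ccc(C)cc1`, differs from compound 2 by methyl in place of bromo on an aromatic carbon. For the measured compounds named here, the one measured step that bears on this is the exchange at the same place on the same ring, a number 4 percentage points higher from compound 1 to compound 2 (within the scatter), where a bromo replaced an ethoxy and the read-out did not move beyond the scatter. Going by the values given here, nothing is known about a methyl at this place, but with the only comparable exchange leaving the number unchanged, the expectation for compound 3 is no step beyond the scatter, estimated as a number 4 percentage points lower from compound 2 to compound 3 (within the scatter). The estimate for compound 3 in this assay is therefore 50%, with a range from 35% to 65%.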

Compound 3, a percentage reported as inhibition, in the whole organism at one dose (the size of the read-out at that dose, not a potency): 55%
Compound 3: the middle estimate sits 5 percentage points below what was measured; the measured number falls inside the stated range.
By their numbers in this assay, from the lowest: compounds 1, 2 and 3 (each within the scatter of the next).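

In this assay, methyl in place of bromo on the aromatic carbon para to a large group gives a number 1 percentage points higher from compound 2 to compound 3 (within the scatter), and methyl in place of ethoxy at that same place gives a number 5 percentage points higher from compound 1 to compound 3 (within the scatter). Where the earlier pair offered only two groups at this position, there are now three, ethoxy, bromo and methyl, and their numbers cannot be told apart, so in these compounds the exchange of one for another leaves the inhibition at this single dose within the scatter. Nothing measured here accounts for this level result, and a number at one dose is not a potency, so the three compounds may still differ at other doses.

On these data alone, it remains open whether a group of a different kind at this place, such as an amine or a carboxylic acid, would move the number beyond the scatter. As far as these compounds go, all three compounds also keep the ethyl group on the shared core, so the effect of a longer chain there, or of a hydrogen in its stead, is still unknown.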